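The source may hold more compounds than are shown below. What is called first, only, known or untested is meant among the compounds shown, and "the series" means these compounds.

In an in vitro ADME assay on microsomes from liver (Homo sapiens) for metabolic stability (a lower number here means slower removal, a higher number faster removal of the compound), compound 1 `CCC(CC)[C@@H]1C(=O)N[C@H](C2Cc3ccccc3C2)C(=O)N1[C@@H](C(=O)N1CCOCC1)c1ccc(C)nc1` gives 12 mL.min-1.g-1. Compound 2 `CCC(CC)[C@@H]1C(=O)N[C@H](C2Cc3ccccc3C2)C(=O)N1[C@@H](C(=O)N1CCOCC1)c1ccc(C)nc1C` gives 11 mL.min-1.g-1 and compound 3 `CCC(CC)[C@@H]1C(=O)N[C@H](C2Cc3ccccc3C2)C(=O)N1[C@@H](C(=O)N(C)C)c1ccc(C)nc1` gives 11 mL.min-1.g-1, so compound 1 stands level with both within the usual scatter. Compound 4 `CC[C@@H](C)[C@@H]1C(=O)N[C@H](C2Cc3ccccc3C2)C(=O)N1[C@@H](C(=O)N1CCOCC1)c1ccc(C)nc1` is still unmeasured. It carries sec-butyl in place of pentan-3-yl on a saturated ring carbon. Going by the values given here, no measured step changes that group, so the evidence is indirect. Methyl in place of hydrogen on an aromatic carbon gave a 1.1-fold lower number from compound 1 to compound 2 (0.04 log units; within the scatter), and dimethylamino in place of morpholin-4-yl gave a 1.1-fold lower number from compound 1 to compound 3 (0.04 log units; within the scatter). Both steps lie within the scatter, so no step beyond the scatter is expected in this assay here. The expected size of the change is a 1.2-fold lower number from compound 1 to compound 4 (0.08 log units; within the scatter). For compound 4 the estimated value is 10 mL.min-1.g-1, with an expected range from 5 mL.min-1.g-1 to 19 mL.min-1.g-1.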

Compound 4, intrinsic clearance in microsomes: 4 mL.min-1.g-1
The estimate for compound 4 lay 2.5-fold (0.40 log units) above the measured number; measured number outside the range, below it.
By their numbers in this assay, from the lowest: compound 4; then compounds 2, 3 and 1 (each within the scatter of the next).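

In this assay, the saturated ring carbon next to the ring nitrogen is the only place among those shown where one change moves the number beyond the scatter: sec-butyl in place of pentan-3-yl gives a 3.0-fold lower number from compound 1 to compound 4 (0.48 log units; beyond the scatter), whereas the changes at the other two places did not. This swap removes one carbon and adds a defined stereocentre, and no measurement shown gives a reason for the step. Still open, as far as these compounds go, is whether a shorter group such as isopropyl or a ring such as cyclopentyl would give a similar number, and whether the opposite stereocentre in sec-butyl would match compound 4.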